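This account rests on a few compounds, and the source may have more. Where it says the series, first, only, none or still open, it means among the compounds named here.

Measured in a functional assay on KB cells (Homo sapiens) for inhibition; on this read-out lower numbers stand for stronger inhibition and higher numbers for weaker inhibition:
- compound 1 `Nc1nc2cc(Cl)c(Cl)cc2n1Cc1ccc(Cl)cc1`: 45000 nM
- compound 2 `Clc1ccc(Cn2c(Cl)nc3cc(Cl)c(Cl)cc32)cc1`: > 100000 nM (a limit of the assay, not a number)

Compound 2 stands at the limit of > 100000 nM in this assay, at which 1 of the 2 values shown sits. Its true position is therefore open on the upper side, and any comparison with it is only approximate.

The next compound to read is compound 3 `FC(F)(F)c1ccc(Cn2c(Cl)nc3cc(Cl)c(Cl)cc32)cc1`. The change from compound 2 is trifluoromethyl in place of chloro on an aromatic carbon, para to a large group. Among the compounds with values here, the group that changes is the same kind of aromatic substituent in neither measured step, so the series holds no direct precedent.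

Within the data shown here, the only measured step is an at least 2.2-fold higher number from compound 1 to compound 2 (0.34 log units; beyond the scatter). That step is chloro in place of amino at another place in the structure, so it bears on the present change only loosely. It shows that the series can move in this assay, but it gives neither a size nor a direction for this swap.

The expectation therefore rests on compound 2 alone, whose limit is > 100000 nM. No step beyond the scatter is expected, and the estimated step is a number no higher from compound 2 to compound 3 (the limit leaves the size open). For compound 3 the estimate is 100000 nM, with an expected range from 40000 nM to 250000 nM, and a report as a limit is quite likely.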

Compound 3, half-maximal inhibitory concentration: > 100000 nM
Compound 3 gave a limit, no number; the forecaster's own chance of this, stated with the estimate: 65%; the middle value lies on the limit itself.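

In this assay compound 3 gives > 100000 nM, a limit of the assay and not a number. Compound 2 is also reported only as a limit, so no step between compound 2 and compound 3 can be read: the limit of > 100000 nM in this assay, at which 2 of the 3 values shown sit.

The compounds shown leave open whether trifluoromethyl in place of chloro on an aromatic carbon changes inhibition at all, and in which direction.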